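A few compounds are considered here, and "the series" means these few. Any claim that something is new, unique, unknown or untested is made for them only; others in the source may bear on it.

Among the compounds with values here, in a functional assay on MOLT-4 cells (Homo sapiens) for cytotoxicity (a higher number here means a weaker inhibitor, a lower number a stronger inhibitor), compound 1 `Cc1ccc(S(=O)(=O)N/C(=N\O)Nc2ccc(Cl)cc2)cc1` gives 6 ug/mL, while compound 2 `N#Cc1c(Cl)cccc1Oc1ccc(S(=O)(=O)N/C(=N\O)Nc2ccc(Cl)cc2)cc1` gives 95 ug/mL, the highest of the two numbers so far. Compound 3 `CCCCOc1ccc(S(=O)(=O)N/C(=N\O)Nc2ccc(Cl)cc2)cc1` has not yet been measured. It departs from compound 2 in one place, with butyl in place of 3-chloro-2-cyanophenyl on an oxygen on an aromatic ring. Within the data shown here, one measured step bears on this change: a 16-fold higher number from compound 1 to compound 2 (1.20 log units; beyond the scatter), a large step beyond the scatter, with 3-chloro-2-cyanophenoxy in place of methyl on an aromatic carbon. Among the measured compounds shown here, the change to compound 3 removes the 3-chloro-2-cyanophenyl group, but no measured compound carries butoxy, so only a partial return of that step is expected. The expected change, toward a lower number, is a 4.3-fold lower number from compound 2 to compound 3 (0.64 log units; beyond the scatter). For compound 3 the estimated value is 22 ug/mL, within a range of 6 ug/mL to 80 ug/mL.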

Compound 3, half-maximal inhibitory concentration: 18 ug/mL
Compound 3: the middle estimate sits 1.2-fold (0.09 log units) above what was measured; the measured number falls inside the stated range.
By their numbers in this assay, from the lowest: compound 1; then compound 3; then compound 2.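

In this assay, the oxygen stays in place while butyl replaces 3-chloro-2-cyanophenyl, giving a 5.3-fold lower number from compound 2 to compound 3 (0.72 log units; beyond the scatter). The high number of compound 2 goes at least partly with the 3-chloro-2-cyanophenyl group. Butoxy does not restore the level seen with methyl on the aromatic carbon, giving a 3.0-fold higher number from compound 1 to compound 3 (0.48 log units; beyond the scatter), so this position is sensitive to more than the ring-bearing group. Nothing available gives a reason for either step.

The compounds shown leave open how much of the remaining gap comes from the oxygen and how much from the butyl chain, which methoxy or a longer alkoxy chain would help to separate. They also leave open whether the ring itself or its chlorine and nitrile drive the higher number, a question that plain phenoxy would address.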